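The compounds below may be only part of what the source reports. "The series", "measured", "known", "first", "only" and "open" are said of these compounds alone.

Compound 1 `CC(C)(C)c1ccc(C(=O)N2CCC3(CC2)C(=O)N(CC(=O)N2CCC(CCO)CC2)CN3c2ccccc2)cc1` is the starting point of this comparison. In an assay on HEK293 cells for displacement of a labelled ligand from NPC1-like intracellular cholesterol transporter 1 (Homo sapiens) (on this read-out lower numbers stand for stronger inhibition and higher numbers for weaker inhibition), compound 1 gives 2600 nM, which is the lowest of the two numbers recorded. Compound 3 `CC(C)(C)OC(=O)NCCCNC(=O)CN1CN(c2ccccc2)C2(CCN(C(=O)c3ccc(C4CCCCC4)cc3)CC2)C1=O` gives 6000 nM in this assay, a number that lies above that of compound 1 by more than the usual scatter of repeated measurements. For compound 2 `CCc1nn(CC)c(C2CCN(C(=O)CN3CN(c4ccccc4)C4(CCN(C(=O)c5ccc(C6CCCCC6)cc5)CC4)C3=O)CC2)c1C` the entry in this assay reads "not determined" (no result reported), so no number exists for it. Compound 1 and compound 3 differ from each other in more than one place, so no single-change step can be read from them.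

Compound 4 `CC(C)(C)c1ccc(C(=O)N2CCC3(CC2)C(=O)N(CC(=O)NCCC(=O)O)CN3c2ccccc2)cc1` differs from compound 1 in exactly one place: (2-carboxyethyl)amino in place of 4-(2-hydroxyethyl)piperidin-1-yl on a carbonyl carbon. For the measured compounds named here, no pair of measured compounds shows this particular exchange, so what can be expected for compound 4 rests on compound 1 alone, with no measured step to lean on. The step of a 2.1-fold higher number from compound 1 to compound 4 (0.33 log units; beyond the scatter) is expected to run toward weaker inhibition, by a margin somewhat beyond the usual scatter but not a large one, and with real uncertainty in both directions. Compound 4 is therefore estimated at 5500 nM in this assay, with a plausible range from 1500 nM to 20000 nM.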

Compound 4, half-maximal inhibitory concentration: 11400 nM
The estimate for compound 4 lay 2.1-fold (0.32 log units) below the measured number; the range from low to high includes it.
By their numbers in this assay, from the lowest: compound 1; then compounds 3 and 4 (each within the scatter of the next).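

For the compounds shown here, the exchange of 4-(2-hydroxyethyl)piperidin-1-yl for (2-carboxyethyl)amino on this carbonyl carbon gives the first single-change step in this set: in this assay it is a 4.4-fold higher number from compound 1 to compound 4 (0.64 log units; beyond the scatter), toward weaker inhibition. The group at this place therefore matters to the read-out, yet the step is only modest, even though the entering group has no ring, has fewer heavy atoms and ends in a carboxylic acid. Nothing measured here explains the loss of inhibition.

This single step bundles several differences, so the compounds shown leave open whether the loss goes with removing the ring, with opening the group into a chain or with the acid at its end. A (3-hydroxypropyl)amino group would keep an open chain but end in a hydroxyl, the methyl ester of the acid would keep the chain while capping the acid, and a piperidin-1-yl ring bearing a carboxylic acid would keep both the ring and the acid, so each would test a different part of the exchange.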